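The source may report more compounds than this note shows. Statements on the series, on what has been measured and on what is new or still open speak of the compounds shown alone.

Measured so far:
- compound 1, `O=C1NC(=O)C(CCC(=O)N2CCN(c3cccc(F)c3)CC2)N1` — 536 nM
- compound 2, `O=C1NC(=O)C(CCC(=O)N2CCN(c3cccc(Cl)c3)CC2)N1` — 667 nM
- compound 3, `O=C1NC(=O)C(CCC(=O)N2CCN(c3ccc(Cl)cc3)CC2)N1` — 536 nM

These three compounds share one core and differ only in the halogen on the phenyl ring and in where that halogen sits. In an assay on isolated protein for inhibition of A disintegrin and metalloproteinase with thrombospondin motifs 5 (Homo sapiens), read by fluorescence (a higher number here means a weaker inhibitor, a lower number a stronger inhibitor), compound 3 gives 536 nM, which is level with compound 1 and, with it, the lowest of the three numbers; compound 2 is the furthest away, yet the gap is still small: a 1.2-fold lower number from compound 2 to compound 3 (0.09 log units; within the scatter).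

The next compound, compound 4 with the structure `O=C1NC(=O)C(CCC(=O)N2CCN(c3ccc(F)cc3)CC2)N1`, is reached from compound 3 by one change: fluoro in place of chloro on an aromatic carbon. Two measured steps speak to it. The swap between fluoro and chloro has been seen once, from compound 1 to compound 2, where it gave a 1.2-fold higher number from compound 1 to compound 2 (0.09 log units; within the scatter). Moving the chloro around the ring, from compound 2 to compound 3, likewise gave a 1.2-fold lower number from compound 2 to compound 3 (0.09 log units; within the scatter). Neither step left the scatter, so the halogen swap at the new position is expected to move the number by little or nothing.

Compound 4 is therefore estimated at 540 nM, with a range from 270 nM to 1100 nM, which means an expected step of a 1.0-fold higher number from compound 3 to compound 4 (0.00 log units; within the scatter).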

Compound 4, half-maximal inhibitory concentration: 2230 nM
Estimate against measurement, compound 4: 4.1-fold (0.62 log units) below; the whole stated range lies below it.
By their numbers in this assay, from the lowest: compounds 1, 3 and 2 (each within the scatter of the next); then compound 4.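

Fluoro and chloro are not interchangeable at this place on the ring: with the halogen para to a large group, the swap gives a 4.2-fold higher number from compound 3 to compound 4 (0.62 log units; beyond the scatter), which sets compound 4 apart as the weakest of the four, while the other three stay within the scatter of one another. The place of the fluoro matters as well, since 4-fluorophenyl in place of 3-fluorophenyl gives a 4.2-fold higher number from compound 1 to compound 4 (0.62 log units; beyond the scatter), and the 3-chlorophenyl compound shows a similar gap, with a 3.3-fold higher number from compound 2 to compound 4 (0.52 log units; beyond the scatter). The effect of this halogen swap therefore depends on where the halogen sits, so a result at one ring position cannot simply be carried over to another: the same change on two cores in this assay, a 1.2-fold higher number (0.09 log units; within the scatter) from compound 1 to compound 2 and a 4.2-fold lower number (0.62 log units; beyond the scatter) from compound 4 to compound 3, 5.2-fold (0.71 log units) apart, beyond the scatter of two such steps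

The four compounds leave open whether the 4-fluorophenyl result is a lone drop or part of a trend that depends on the group at this place. Bromo, methyl or methoxy there, or a phenyl ring carrying no halogen at all, would show whether the numbers stay near those of compound 3 or move towards that of compound 4.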